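Bromo to Methoxy on a Second Core: An Expected Step

The source may report more compounds than this note shows. Statements on the series, on what has been measured and on what is new or still open speak of the compounds shown alone.

Of the compounds shown here, three have been measured in a functional assay on WM 266-4 cells (Homo sapiens) for inhibition, read by MTT assay, with a stated time of 24 h; a lower number here means a stronger inhibitor of growth, a higher number a weaker inhibitor of growth. Compound 1, `COc1ccc(C2=NN(C(=O)C3COc4ccccc4O3)C(c3cccc(F)c3)C2)cc1`, gives 6720 nM. Compound 3, `O=C(C1COc2ccccc2O1)N1N=C(c2ccc(Br)cc2)CC1c1cccc(F)c1`, gives 7810 nM in this assay. Compound 2, `COc1ccc(C2CC(c3ccc(Br)cc3)=NN2C(=O)c2ccc3c(c2)OCCO3)cc1`, gives 5680 nM in this assay, the lowest of the three numbers, although its gaps to compound 1 and to compound 3 are both within the scatter, so no ranking among the three can be read from these figures.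

Compound 3 and compound 1 share a core and differ in a single place: methoxy in place of bromo on an aromatic carbon. In this assay that change produced a 1.2-fold lower number from compound 3 to compound 1 (0.07 log units; within the scatter), a step that is itself within the scatter.

Compound 4, `COc1ccc(C2=NN(C(=O)c3ccc4c(c3)OCCO4)C(c3ccc(OC)cc3)C2)cc1`, has not yet been measured. It relates to compound 2 as compound 1 relates to compound 3: methoxy in place of bromo on an aromatic carbon. The surroundings of the change read the same in both pairs, so this is the same change carried onto a second core. How the core of compound 2 differs from the core of compound 3 is not broken down here.

Because the earlier pair gave a 1.2-fold lower number from compound 3 to compound 1 (0.07 log units; within the scatter), the step now expected is a 1.1-fold lower number from compound 2 to compound 4 (0.06 log units; within the scatter). Compound 4 is accordingly estimated at 5000 nM in this assay, with a range expected from 2500 nM to 10000 nM.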

Compound 4, concentration for 50% growth inhibition: 9890 nM
Estimate against measurement, compound 4: 2.0-fold (0.30 log units) below; the measured number falls inside the stated range.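

In this assay, the exchange of 4-bromophenyl for 4-methoxyphenyl on the second core gave a 1.7-fold higher number from compound 2 to compound 4 (0.24 log units; within the scatter), a step that does not stand clear of the variation between repeated measurements. Set beside the step on the first core, it carries the opposite sign as printed, yet the gap between the two steps cannot be told apart from scatter: the same change on two cores in this assay, a 1.2-fold lower number (0.07 log units; within the scatter) from compound 3 to compound 1 and a 1.7-fold higher number (0.24 log units; within the scatter) from compound 2 to compound 4, 2.0-fold (0.31 log units) apart, within the scatter of two such steps. The two pairs are therefore compatible with the change carrying over from one core to the other, with no step beyond the scatter on either core, but they do not show that the step is the same on both cores, nor that it depends on the core.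

The compounds shown hold only bromo and methoxy at this place, so it remains open whether an amine, a carboxylic acid or a longer chain such as butoxy on the same aromatic carbon would give a step that stands beyond the scatter on either core. Also open, going by these compounds, is how the change reads on any third core, and which of the several differences between the two cores, taken singly, would matter in this assay.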